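The source may report more compounds than this note shows. Statements on the series, on what has been measured and on what is new or still open speak of the compounds shown alone.

The measured compounds:

Compound 1, `C=C(c1ccc(OC)cc1NC(=O)CNCC)c1ccc(OC)c2c1OC(C)(C)C=C2`, gives 1090 nM in a functional assay on HeLa cells (Homo sapiens) for antiproliferative activity, read by MTT assay, with a stated time of 48 h; on this read-out lower numbers stand for stronger inhibition and higher numbers for weaker inhibition.
Compound 2, `C=C(c1ccc(OC)cc1NC(=O)CNCC)c1ccc(OC)c2c1C=CC(C)(C)O2`, gives 2590 nM in this assay.
Compound 3, `C=C(c1ccc(OC)cc1NC(=O)CN(C)C)c1ccc(OC)c2c1OC(C)(C)C=C2`, gives 900 nM in this assay.

Compound 1 and compound 3 are built on the same core and differ in a single place, namely (dimethylamino in place of ethylamino on a saturated chain carbon bound to a carbonyl carbon). That change made a step of a 1.2-fold lower number from compound 1 to compound 3 (0.08 log units; within the scatter), so the two compounds cannot be told apart on this read-out. Compound 2 carries a different core; the difference between the two cores is not broken down here. Its number in this assay is the highest of the three, and its distance from compound 1 lies beyond the scatter, so compound 2 inhibits growth more weakly than compound 1 and than compound 3.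

Compound 4, `C=C(c1ccc(OC)cc1NC(=O)CN(C)C)c1ccc(OC)c2c1C=CC(C)(C)O2`, has not been measured. It stands to compound 2 exactly as compound 3 stands to compound 1: the difference is dimethylamino in place of ethylamino on a saturated chain carbon bound to a carbonyl carbon, made at the same place, so it is the same change rather than merely the same kind. Nothing in the data says whether the change behaves differently on the core of compound 2. Among the compounds with values here, the only guide is the measured pair, so a step of a 1.2-fold lower number from compound 2 to compound 4 (0.07 log units; within the scatter) is expected, resting on the step of a 1.2-fold lower number from compound 1 to compound 3 (0.08 log units; within the scatter) seen on the other core. On that basis compound 4 is expected to give about 2200 nM in this assay, estimated to fall between 1100 nM and 4400 nM.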

Compound 4, half-maximal inhibitory concentration: 790 nM
Compound 4: middle estimate off by 2.8-fold (0.44 log units), on the high side; the whole stated range lies above it.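

In this assay, putting dimethylamino in place of ethylamino on the core of compound 2 gives a 3.3-fold lower number from compound 2 to compound 4 (0.52 log units; beyond the scatter). Within the data shown here, the same change does not carry over from one core to the other with the same size, so a step measured on one core was a poor guide to the step on the other: the same change on two cores in this assay, a 1.2-fold lower number (0.08 log units; within the scatter) from compound 1 to compound 3 and a 3.3-fold lower number (0.52 log units; beyond the scatter) from compound 2 to compound 4, 2.7-fold (0.43 log units) apart, beyond the scatter of two such steps This comparison rests on only one pair of compounds per core, and it does not show why the two cores respond differently, which part of the difference between them matters, or whether any other change would behave the same way.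

The compounds shown carry only ethylamino and dimethylamino on the saturated chain carbon bound to a carbonyl carbon, so it remains open whether a ring amine such as pyrrolidine or morpholine would also give steps of different size on the two cores. On these data alone, it also remains open what a plain primary amine or a longer chain on the nitrogen, as in diethylamino, would do at that place on each core.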